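Swapping the aryl group on a kinase-binding core

A few compounds are considered here, and "the series" means these few. Any claim that something is new, unique, unknown or untested is made for them only; others in the source may bear on it.

Compound 1 `CCCS(=O)(=O)Nc1ccc(F)c(C(=O)c2n[nH]c3ncc(-c4cccc(F)c4)cc23)c1F` is measured in an assay for binding affinity to dual specificity mitogen-activated protein kinase kinase 4 (Homo sapiens), read by KINOMEscan, tested at 100 nM (on this read-out higher numbers stand for a weaker effect at the one concentration tested and lower numbers for a stronger effect), where compound 1 gives 8.2%. Among the three compounds measured it has the highest of the three numbers, yet both neighbours sit within the usual scatter of it. Compound 2 `CCCS(=O)(=O)Nc1ccc(F)c(C(=O)c2n[nH]c3ncc(-c4ccc(OC)cc4)cc23)c1F` gives 4.2% in this assay, and compound 3 `CCCS(=O)(=O)Nc1ccc(F)c(C(=O)c2n[nH]c3ncc(-c4cccc(N)c4)cc23)c1F` gives 1.6%. The step of a number 4 percentage points lower from compound 1 to compound 2 (within the scatter) and the step of a number 6.6 percentage points lower from compound 1 to compound 3 (within the scatter) are therefore both too small to count as real changes, as is the step of a number 2.6 percentage points lower from compound 2 to compound 3 (within the scatter).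

Compound 4 `CCCS(=O)(=O)Nc1ccc(F)c(C(=O)c2n[nH]c3ncc(-c4ccc(C(C)C)cc4)cc23)c1F` is not yet measured. It differs from compound 1 in one place: 4-isopropylphenyl in place of 3-fluorophenyl on an aromatic carbon. The two steps that bear on this are the change from compound 1 to compound 2, which also replaces the whole 3-fluorophenyl group by another substituted phenyl, and the step from compound 2 to compound 3. Neither moved the read-out beyond the scatter, so no shift beyond the scatter is expected from the new 4-isopropylphenyl group either.

Compound 4 is therefore expected to give about 6% in this assay, within a range from 1% to 18%. This estimate implies the step of a number 2.2 percentage points lower from compound 1 to compound 4 (within the scatter), expected to lie within the scatter.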

Compound 4, a percentage reported as activity, at one concentration (the size of the read-out at that concentration, not a potency): 17%
Compound 4: the middle estimate sits 11 percentage points below what was measured; measured number inside the range.
By their numbers in this assay, from the lowest: compounds 3, 2, 1 and 4 (each within the scatter of the next, the first and the last beyond it).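

In this assay, among the compounds shown here, changing the aryl group at this position can move the read-out after all: swapping methoxy for isopropyl gives a number 12.8 percentage points higher from compound 2 to compound 4 (beyond the scatter) and replacing 3-aminophenyl with 4-isopropylphenyl gives a number 15.4 percentage points higher from compound 3 to compound 4 (beyond the scatter) and these are the first steps here to pass the scatter, though both are modest. Replacing 3-fluorophenyl with the same group gives only a number 8.8 percentage points higher from compound 1 to compound 4 (within the scatter) so compound 1 stays within the scatter of all three other compounds, and the separation exists only between the two ends of the series. Nothing available here explains why the isopropyl group goes with the higher number.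

From the compounds shown here alone, it remains open whether the difference follows the isopropyl group itself or would also appear with other groups on the same phenyl ring, such as a tert-butyl, a carboxylic acid or a dimethylamino group. These numbers also come from one concentration, so they do not show how far the compounds differ in potency.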